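This account rests on a few compounds, and the source may have more. Where it says the series, first, only, none or still open, it means among the compounds named here.

Measured so far in an assay on membranes from brain for binding affinity to Adrenergic receptor alpha-1 (Rattus norvegicus); on this read-out lower numbers stand for stronger inhibition and higher numbers for weaker inhibition:
- compound 1 `Oc1ccc2[nH]c(CN3CCC(Cc4ccccc4F)CC3)nc2c1` gives 730 nM
- compound 2 `Oc1ccc2[nH]c(CN3CCC(Cc4cccc(F)c4)CC3)nc2c1` gives 520 nM
- compound 3 `Oc1ccc2[nH]c(CN3CCC(Cc4c(F)cccc4F)CC3)nc2c1` gives 2600 nM

Compound 3 stands at the highest number of the three in this assay: the steps of a 3.6-fold higher number from compound 1 to compound 3 (0.55 log units; beyond the scatter) and a 5.0-fold higher number from compound 2 to compound 3 (0.70 log units; beyond the scatter) both run upward and both lie beyond the scatter, whereas the step of a 1.4-fold lower number from compound 1 to compound 2 (0.15 log units; within the scatter) stays within it.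

Compound 4 `Cc1ccc(CC2CCN(Cc3nc4cc(O)ccc4[nH]3)CC2)cc1` differs from compound 3 by 4-methylphenyl in place of 2,6-difluorophenyl on a saturated chain carbon bound to a saturated ring carbon. Within the data shown here, no measured step moves between a difluorophenyl and a methylphenyl, so the closest guidance is indirect: the two monosubstituted rings of compound 1 and compound 2 sit close together, and adding the second fluorine to reach compound 3 raised the number by a 3.6-fold higher number from compound 1 to compound 3 (0.55 log units; beyond the scatter). Replacing the 2,6-difluorophenyl with another singly substituted ring is therefore expected to bring the number back toward the range of compound 1 and compound 2, a downward step in this assay of roughly a 3.7-fold lower number from compound 3 to compound 4 (0.57 log units; beyond the scatter). The estimate for compound 4 in this assay is 700 nM, with a range from 250 nM to 2500 nM.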

Compound 4, half-maximal inhibitory concentration: 830 nM
The estimate for compound 4 lay 1.2-fold (0.07 log units) below the measured number; measured number inside the range.
By their numbers in this assay, from the lowest: compounds 2, 1 and 4 (each within the scatter of the next); then compound 3.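

In this assay the 4-methylphenyl ring of compound 4 falls in with the singly fluorinated rings, since a 1.1-fold higher number from compound 1 to compound 4 (0.06 log units; within the scatter) and a 1.6-fold higher number from compound 2 to compound 4 (0.20 log units; within the scatter) both stay within the scatter, so a fluoro group on this ring is not needed to hold the number in that range. With a 3.1-fold lower number from compound 3 to compound 4 (0.50 log units; beyond the scatter) lying beyond the scatter, the 2,6-difluorophenyl alone stands apart among the four rings shown. Nothing at hand bears on why this ring stands apart.

Going by these compounds, how far this tolerance extends remains open, for example to a 4-chlorophenyl, a 4-methoxyphenyl or a ring carrying an amine or a carboxylic acid. Also open, on these data alone, is whether a 2,6-dimethylphenyl would match the 2,6-difluorophenyl or the singly substituted rings.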